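Sulfamate in place of sulfate on the cyclohexanone-chain core

This account rests on a few compounds, and the source may have more. Where it says the series, first, only, none or still open, it means among the compounds named here.

Compound 1 `O=S(=O)(O)O[C@@H]1[C@H](O)C[C@@H](O)C[C@H]1OCCCCc1ccccc1O`: in an assay on isolated protein for inhibition of inositol monophosphatase 1 (Bos taurus) (a lower number here means a stronger inhibitor, a higher number a weaker inhibitor), compound 1 gives 90000 nM.
Compound 2 `NS(=O)(=O)O[C@@H]1[C@H](O)C[C@@H](O)C[C@H]1OCCCCc1ccccc1O`: in this assay compound 2 gives only the assay limit, > 300000 nM.
Compound 3 `O=C1CCCCC1CCCCO[C@@H]1C[C@H](O)C[C@@H](O)[C@H]1OS(=O)(=O)O`: in this assay compound 3 gives 100000 nM.

Compound 3 holds the highest of the two actual numbers, with compound 1 nearest; the step of a 1.1-fold higher number from compound 1 to compound 3 (0.05 log units; within the scatter) stays within the scatter, so the two cores read as equivalent here. The third value is a limit and not a number.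

Compound 4 `NS(=O)(=O)O[C@@H]1[C@H](O)C[C@@H](O)C[C@H]1OCCCCC1CCCCC1=O` differs from compound 3 by amino in place of hydroxy on a sulfonyl sulfur. The same change has been measured once, on the core of compound 1: an at least 3.3-fold higher number from compound 1 to compound 2 (0.52 log units; beyond the scatter). That step ran into the assay limit, (the limit of > 300000 nM in this assay, at which 1 of the 3 values shown sits), so its true size is not known; only its lower bound is.

On the core of compound 3 the same change is therefore expected to weaken inhibition by at least a comparable amount, a 4.0-fold higher number from compound 3 to compound 4 (0.60 log units; beyond the scatter). Compound 4 is expected to give about 400000 nM, within 150000 nM to 1500000 nM, and most likely the assay will again report only a limit.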

Compound 4, half-maximal inhibitory concentration: 200000 nM
Compound 4: the middle estimate sits 2.0-fold (0.30 log units) above what was measured; measured number inside the range.
By their numbers in this assay, from the lowest: compounds 1, 3 and 4 (each within the scatter of the next, the first and the last beyond it). At a limit, above all of these: compound 2.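

On the core of compound 3, amino in place of hydroxy on a sulfonyl sulfur now has a measured size rather than only a floor, and that size stays within the scatter: a 2.0-fold higher number from compound 3 to compound 4 (0.30 log units; within the scatter). In this assay, the sulfooxy and sulfamoyloxy compounds on this core therefore do not separate, and the comparison with the other core remains unsettled: the same change on two cores in this assay, an at least 3.3-fold higher number (0.52 log units; beyond the scatter) from compound 1 to compound 2 and a 2.0-fold higher number (0.30 log units; within the scatter) from compound 3 to compound 4; the limit leaves it open whether they differ. With the sulfamoyloxy group in place, 2-oxocyclohexyl in place of 2-hydroxyphenyl gives only a floor, and that floor does not establish a difference: an at least 1.5-fold lower number from compound 2 to compound 4 (0.17 log units; that floor lies within the scatter).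

On these data alone, the true value of compound 2 stays open, so the size of both steps that involve it does too: the limit of > 300000 nM in this assay, at which 1 of the 4 values shown sits. As far as these compounds go, how a carboxylic acid or a phosphate in place of the sulfooxy group, or a longer chain, would read in this assay also stays open.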